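Chromanol thiazolidinedione series: removal of methoxy

The compounds below may be only part of what the source reports. "The series", "measured", "known", "first", "only" and "open" are said of these compounds alone.

Measured compounds:
compound 1 `Cc1c(C)c2c(c(C)c1OCc1ccccc1)CCC(C)(COc1ccc(/C=C3\SC(=O)NC3=O)cc1)O2` — 42%
compound 2 `COc1cc(/C=C2\SC(=O)NC2=O)ccc1OCC1(C)CCc2c(C)c(OCC=C(C)C)c(C)c(C)c2O1` — 78%

In a functional assay on MCF7 cells (Homo sapiens), tested at 5 uM (on this read-out lower numbers stand for a stronger effect and higher numbers for a weaker effect at the one concentration tested), compound 2 gives 78%, the higher of the two numbers recorded so far; compound 1 gives 42% in this assay, a gap reported as beyond the scatter. For the measured compounds named here, no step between measured compounds is given for any pair, so only these two values stand.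

Compound 3 `CC(C)=CCOc1c(C)c(C)c2c(c1C)CCC(C)(COc1ccc(/C=C3\SC(=O)NC3=O)cc1)O2` has not yet been measured in this assay. Relative to compound 2 it differs as follows: hydrogen in place of methoxy on an aromatic carbon.

Going by the values given here, no measured pair isolates this change. Compound 1 also carries hydrogen at this position, and its value in this assay is lower than that of compound 2, so a lower number for compound 3 is expected, though a wide range has to be allowed. The expected step of a number 20 percentage points lower from compound 2 to compound 3 (beyond the scatter) is downward, moderate, beyond the scatter. Compound 3 is estimated at 58% in this assay, within 38% to 80%.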

Compound 3, a percentage reported as activity, at one concentration (the size of the read-out at that concentration, not a potency): 21%
For compound 3 the middle estimate is 37 percentage points above the measured one; the whole stated range lies above it.
By their numbers in this assay, from the lowest: compound 3; then compound 1; then compound 2.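

In this assay hydrogen in place of methoxy on an aromatic carbon now reads as a single change: the result is a number 57 percentage points lower from compound 2 to compound 3 (beyond the scatter), whereas compound 1 and compound 2 differ in more than one place and could not isolate it. With 2-methylprop-1-en-1-yl in place of phenyl on a saturated chain carbon bound to an oxygen on an aromatic ring, the series also gains a second single-place comparison: a number 21 percentage points lower from compound 1 to compound 3 (beyond the scatter), a modest step against the large one for methoxy loss. Nothing on hand explains either step.

The compounds shown leave open whether methoxy loss gives a step of similar size when the phenyl group is present. Also open, going by these compounds, is how an amine, a hydroxyl or a fluorine on the same aromatic carbon would compare with hydrogen and methoxy.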